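Moving the Ring Nitrogen of a Hydrazone Series

A few compounds are considered here, and "the series" means these few. Any claim that something is new, unique, unknown or untested is made for them only; others in the source may bear on it.

Compound 1 `COc1ccccc1-c1nnc(-c2ccc(C(=O)N/N=C/c3ccccn3)cc2)o1` is the reference point of this small set. Within the data shown here, in an ADME assay on THP-1 cells (Homo sapiens) for cytotoxicity (a lower number here means a stronger inhibitor, a higher number a weaker inhibitor), compound 1 gives 67000 nM, the lowest of the three numbers measured so far. Compound 2 `COc1ccccc1-c1nnc(-c2ccc(C(=O)N/N=C/c3cccc(O)c3)cc2)o1` gives 398000 nM in this assay, and compound 3 `COc1ccccc1-c1nnc(-c2ccc(C(=O)N/N=C/c3ccc(O)c(O)c3)cc2)o1` gives 100000 nM. The two measured steps away from compound 1 are a 5.9-fold higher number from compound 1 to compound 2 (0.77 log units; beyond the scatter) and a 1.5-fold higher number from compound 1 to compound 3 (0.17 log units; within the scatter); between the other two compounds there is a 4.0-fold lower number from compound 2 to compound 3 (0.60 log units; beyond the scatter).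

Compound 4 `COc1ccccc1-c1nnc(-c2ccc(C(=O)N/N=C/c3cccnc3)cc2)o1` has not yet been measured. It differs from compound 1 in one place: pyridin-3-yl in place of pyridin-2-yl on a carbon with a double bond to nitrogen. Among the measured compounds shown here, none of the measured steps exchanges one pyridinyl for another; each of them puts 3-hydroxyphenyl or 3,4-dihydroxyphenyl in place of pyridin-2-yl, or hydroxy in place of hydrogen. Because a 5.9-fold higher number from compound 1 to compound 2 (0.77 log units; beyond the scatter) was only modest and a 1.5-fold higher number from compound 1 to compound 3 (0.17 log units; within the scatter) lay within the scatter, a small step with no clear direction is expected for pyridin-3-yl in place of pyridin-2-yl. Compound 4 is therefore estimated at 90000 nM, within a range of 35000 nM to 250000 nM. That estimate corresponds to an expected step of a 1.3-fold higher number from compound 1 to compound 4 (0.13 log units; within the scatter).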

Compound 4, half-maximal inhibitory concentration: 167000 nM
Beside the measured number, compound 4's estimate is 1.9-fold (0.27 log units) below it; the range from low to high includes it.
By their numbers in this assay, from the lowest: compounds 1, 3 and 4 (each within the scatter of the next, the first and the last beyond it); then compound 2.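

Moving the ring nitrogen alone, with the same atoms joined differently, registers in this assay (a 2.5-fold higher number from compound 1 to compound 4 (0.40 log units; beyond the scatter)), so the group on the carbon with a double bond to nitrogen matters here not only by which ring it is but also by where that ring carries its nitrogen. Set against the two hydroxylated rings, pyridin-3-yl separates from 3-hydroxyphenyl (a 2.4-fold lower number from compound 2 to compound 4 (0.38 log units; beyond the scatter)) but not from 3,4-dihydroxyphenyl (a 1.7-fold higher number from compound 3 to compound 4 (0.22 log units; within the scatter)). Nothing available explains why the position of the nitrogen makes this difference.

Still open, on these data alone, is whether pyridin-4-yl in the same place would fall with compound 1, with compound 4 or elsewhere. As far as these compounds go, it is also open whether an unsubstituted phenyl, or a ring bearing an amine or a carboxylic acid, would move the number further.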